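A few compounds are considered here, and "the series" means these few. Any claim that something is new, unique, unknown or untested is made for them only; others in the source may bear on it.

Measured so far in a toxicity assay on MT2 cells (Homo sapiens) for cytotoxicity, read by MTT assay; on this read-out lower numbers stand for higher toxicity in this test and higher numbers for lower toxicity in this test:
Compound 1, `N#Cc1cc2c(Oc3ccc(F)cc3OCCn3ccc(=O)[nH]c3=O)cc(F)cn2c1`, gives 50000 nM.
Compound 2, `Cc1cc(Oc2ccccc2OCCn2ccc(=O)[nH]c2=O)c(Cl)c2cc(C#N)ccc12`, reaches only a limit of the test, > 100000 nM.
Compound 3, `CCCc1cc(Oc2ccccc2OCCn2ccc(=O)[nH]c2=O)c(C)c2cc(C#N)ccc12`, gives 15000 nM.

Compound 3 holds the lowest of the two numbers, and the gap to compound 1 lies beyond the usual scatter. The value of compound 2 is a limit, not a number.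

Compound 4, `CCOc1cc(Oc2ccccc2OCCn2ccc(=O)[nH]c2=O)c(C)c2cc(C#N)ccc12`, has not yet been tested. It differs from compound 3 by ethoxy in place of propyl on an aromatic carbon. Among the compounds with values here, no measured pair shows this kind of exchange, so the expectation rests on compound 3 alone, and no shift beyond the scatter is expected in this assay. Compound 4 is expected to give about 20000 nM, likely between 8000 nM and 60000 nM. This estimate means a step of a 1.3-fold higher number from compound 3 to compound 4 (0.12 log units; within the scatter).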

Compound 4, half-maximal cytotoxic concentration: > 100000 nM
Compound 4 gave a limit, no number; the forecaster's own chance of this, stated with the estimate: 15%; middle value at least 5.0-fold (0.69 log units) from the limit.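

In this assay, putting ethoxy in place of propyl on this aromatic carbon gives an at least 6.6-fold higher number from compound 3 to compound 4 (0.82 log units; beyond the scatter) and so shows that the read-out responds to a change at this position, even though both groups have 3 heavy atoms. Compound 4 reaches only a limit of the test (> 100000 nM), not a number. The full size of the step therefore stays unknown, as the value sits at that limit: the limit of > 100000 nM in this assay, at which 2 of the 4 values shown sit.

As far as these compounds go, it remains open what a methoxy group, a longer chain such as butyl, or an amine would give at this position.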